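Swapping a nitrile for a methyl on the benzyl group

The compounds below may be only part of what the source reports. "The series", "measured", "known", "first", "only" and "open" are said of these compounds alone.

Three compounds share a core in which a piperidine amide is capped by an acyl sulfonamide, and all were tested in a functional assay (Platelet, plasma) for inhibition, with Homo sapiens as the target; a higher number here means a weaker inhibitor, a lower number a stronger inhibitor. Compound 1 `N#Cc1ccc(CS(=O)(=O)NC(=O)C2CCN(c3nc4c(cc3C#N)C(=O)OC4)CC2)cc1` gives 8900 nM and stands second highest of the three numbers. Compound 2 `N#Cc1cc2c(nc1N1CCC(F)(C(=O)NS(=O)(=O)c3ccc(Cl)s3)CC1)COC2=O` gives 37100 nM, the weakest result here, while compound 3 `N#Cc1cc2c(nc1N1CCC(F)(C(=O)NS(=O)(=O)Cc3ccccc3)CC1)COC2=O` gives 1210 nM, the strongest. Within the data shown here, the one single-point step among them, a 31-fold lower number from compound 2 to compound 3 (1.49 log units; beyond the scatter), concerns what sits on the sulfonyl sulfur, not a substituent on the benzyl ring, so it does not bear directly on the change at hand.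

Compound 4 `Cc1ccc(CS(=O)(=O)NC(=O)C2CCN(c3nc4c(cc3C#N)C(=O)OC4)CC2)cc1` differs from compound 1 by methyl in place of cyano on an aromatic carbon. Among the measured compounds shown here, no measured pair isolates this swap; compound 3, which carries a plain benzyl but also a fluorine on the piperidine, only shows that a benzyl without the nitrile can give a lower number than compound 1. On that thin basis, a small step, likely toward a lower number, is expected: a 1.8-fold lower number from compound 1 to compound 4 (0.25 log units; within the scatter). Compound 4 is therefore estimated at 5000 nM, within a range of 1500 nM to 16000 nM.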

Compound 4, half-maximal inhibitory concentration: 4280 nM
Estimate against measurement, compound 4: 1.2-fold (0.07 log units) above, and the stated range covers the measured number.
By their numbers in this assay, from the lowest: compound 3; then compound 4; then compound 1; then compound 2.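

In this assay, among these compounds, the first pair to isolate this change shows that replacing cyano with methyl on the aromatic carbon para to a large group gives a 2.1-fold lower number from compound 1 to compound 4 (0.32 log units; beyond the scatter). This step is modest but beyond the usual scatter, so the number at this position does respond to the group placed there, and the nitrile is not needed for compound 4 to inhibit in this assay. Nothing available explains why the number moves in this direction.

As far as these compounds go, what a methoxy group, an amine or a carboxylic acid would do at this position remains open, as does the result with only hydrogen there. Also open, from the compounds shown here alone, is whether the same swap would give a step of similar size on a core carrying the fluorine on the piperidine, as in compound 3.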